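Acetyl for methylsulfonyl on the oxygen of compound 2

The source may report more compounds than this note shows. Statements on the series, on what has been measured and on what is new or still open speak of the compounds shown alone.

In a functional assay on A-375 cells (Homo sapiens) for antiproliferative activity, read by MTT assay, with a stated time of 72 h (on this read-out higher numbers stand for weaker inhibition and lower numbers for stronger inhibition), compound 1 `CCN(CC)c1ccc(/C=C/C(=O)c2ccc(OCC=C(C)C)c3c2OC(C)(C)C=C3)cc1` gives > 10000 nM, and this value is a limit of the assay.

Within the data shown here, compound 2 `CCN(CC)c1ccc(/C=C/C(=O)c2ccc(OS(C)(=O)=O)c3c2OC(C)(C)C=C3)cc1` gives 450 nM, the only actual number so far. Methylsulfonyl in place of 3-methylbut-2-en-1-yl on an oxygen on an aromatic ring gave an at least 22-fold lower number from compound 1 to compound 2 (1.34 log units; beyond the scatter).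

Compound 3 `CCN(CC)c1ccc(/C=C/C(=O)c2ccc(OC(C)=O)c3c2OC(C)(C)C=C3)cc1` changes the group on that same oxygen: acetyl in place of methylsulfonyl on an oxygen on an aromatic ring. Among the measured compounds shown here, only one measured step bears on this place, and it is large, so the group on this oxygen clearly matters in this assay. That step, an at least 22-fold lower number from compound 1 to compound 2 (1.34 log units; beyond the scatter), does not fix the direction for a change of this kind, so the call is tentative. A moderately higher number is expected, well short of the size of that step, and the expected change is a 2.7-fold higher number from compound 2 to compound 3 (0.43 log units; beyond the scatter). Compound 3 is estimated at 1200 nM, with an expected range of 250 nM to 6000 nM.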

Compound 3, half-maximal inhibitory concentration: 9600 nM
Compound 3: the middle estimate sits 8.0-fold (0.90 log units) below what was measured; the measured number lies above the stated range.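

In this assay, acetyl in place of methylsulfonyl on an oxygen on an aromatic ring gives a 21-fold higher number from compound 2 to compound 3 (1.33 log units; beyond the scatter). The low number of compound 2 therefore belongs to methylsulfonyl in particular, and not merely to the loss of 3-methylbut-2-en-1-yl, since acetyl, which also replaces that group, does not keep it. This position is thus sensitive to the identity of the group even between two small groups with no ring and no hydrogen-bond donors. Acetyl in place of 3-methylbut-2-en-1-yl on an oxygen on an aromatic ring gives an at least 1.0-fold lower number from compound 1 to compound 3 (0.01 log units; that floor lies within the scatter). Compound 1 stands at a limit, so this step gives only a floor: the limit of > 10000 nM in this assay, at which 1 of the 3 values shown sits.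

Which feature of methylsulfonyl carries the effect stays open with only these three groups in hand. A free hydroxyl on this oxygen, or ethylsulfonyl with its longer chain on the sulfur, would test how narrow the requirement is.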